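Vero cytotoxicity limits across a trifluoromethyl-to-fluoro change

The source may hold more compounds than are shown below. What is called first, only, known or untested is meant among the compounds shown, and "the series" means these compounds.

Compound 1 `O=[N+]([O-])c1cn2c(n1)OC[C@@H](OCc1ccc(-c3ccc(C(F)(F)F)cc3)s1)C2`, compound 2 `O=[N+]([O-])c1cn2c(n1)OC[C@@H](OCc1ccc(-c3ccc(F)cc3)s1)C2` and compound 3 `O=[N+]([O-])c1cn2c(n1)OC[C@@H](OCc1nnn(-c3ccc(C(F)(F)F)cc3)n1)C2` have each been run in an ADME assay on Vero cells (Chlorocebus sabaeus) for cytotoxicity, with a stated time of 72 h; a lower number here means a stronger inhibitor, a higher number a weaker inhibitor. Compound 1 returns only a limit in this assay, > 128000 nM. Compound 2 likewise gives nothing but a limit, > 128000 nM. Compound 3 also stands at a limit, > 128000 nM. Going by the values given here, every value so far rests on (the limit of > 128000 nM in this assay, at which 3 of the 3 values shown sit), so no ordering among the three can be drawn.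

Compound 1 and compound 2 differ by fluoro in place of trifluoromethyl on an aromatic carbon. The step that the two limits leave unreadable from compound 1 to compound 2 is therefore unreadable: both ends are limits. The difference between the core of compound 1 and the core of compound 3 is not broken down here.

Compound 4 `O=[N+]([O-])c1cn2c(n1)OC[C@@H](OCc1nnn(-c3ccc(F)cc3)n1)C2` has not yet been measured in this assay. Compound 4 differs from compound 3 by fluoro in place of trifluoromethyl on an aromatic carbon, and the place of that change is described in the same words as for the change from compound 1 to compound 2, so it is the same change made on a different core. Since the earlier occurrence of this change could not be sized, and since all measured values sit at the limit of > 128000 nM in this assay, at which 3 of the 3 values shown sit, the step from compound 3 to compound 4 is expected to be essentially flat, a step that the limit leaves unreadable from compound 3 to compound 4. Compound 4 is accordingly expected to give about 130000 nM in this assay. The expected span for compound 4 is estimated to run from 50000 nM to 300000 nM, with a strong chance that only a limit is reported.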

Compound 4, half-maximal inhibitory concentration: > 128000 nM
Compound 4 gave a limit, no number (the forecaster's own chance of this, stated with the estimate: 85%); the middle value is on the limit's open side.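

Compound 3 and compound 4 both return only limits in this assay, so the step between them cannot be read, and the same holds for compound 1 and compound 2: the limit of > 128000 nM in this assay, at which 4 of the 4 values shown sit.

The compounds shown leave open at what concentration, if any, any of the four would give a number in this assay, and whether fluoro in place of trifluoromethyl has any size on either core.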